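Diaryl urea series: fluoro for hydrogen at the aryloxy ring

This account rests on a few compounds, and the source may have more. Where it says the series, first, only, none or still open, it means among the compounds named here.

Measured so far:
Compound 1 `CNc1cc(Oc2ccc(NC(=O)Nc3cccc(C(F)(F)F)c3)cc2Cl)ncn1` — 50 nM in an assay on isolated protein for inhibition of serine/threonine-protein kinase TNNI3K (Homo sapiens); a higher number here means a weaker inhibitor, a lower number a stronger inhibitor
Compound 2 `CNc1cc(Oc2ccc(NC(=O)Nc3cccc(C(F)(F)F)c3)cc2)ncn1` — 40 nM in this assay

Among the measured compounds shown here, compound 2 gives the lower of the two numbers so far in this assay, but the step of a 1.3-fold lower number from compound 1 to compound 2 (0.10 log units; within the scatter) is within the scatter, so the two compounds cannot be told apart on these data. That step is the only one that bears on the next change: hydrogen in place of chloro at the same place on the aromatic carbon.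

Compound 3 `CNc1cc(Oc2ccc(NC(=O)Nc3cccc(C(F)(F)F)c3)cc2F)ncn1` differs from compound 2 by fluoro in place of hydrogen on an aromatic carbon. For the measured compounds named here, the one measured step at this position, chloro to hydrogen, moved the number by less than the scatter, so a small halogen entering where hydrogen leaves is not expected to produce a step beyond the scatter in this assay either. For compound 3 the expected step is no change at the digits printed from compound 2 to compound 3 (within the scatter), essentially flat. Compound 3 is therefore estimated at 40 nM, with a range of 20 nM to 80 nM.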

Compound 3, half-maximal inhibitory concentration: 25 nM
Compound 3: middle estimate off by 1.6-fold (0.20 log units), on the high side; measured number inside the range.
By their numbers in this assay, from the lowest: compounds 3, 2 and 1 (each within the scatter of the next).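

Among the compounds shown here, with fluoro now at this place, ortho to a (6-(methylamino)pyrimidin-4-yl)oxy group, the series holds three substituents there, and the comparison extends beyond the single chloro-to-hydrogen step: fluoro in place of hydrogen gives a 1.6-fold lower number from compound 2 to compound 3 (0.20 log units; within the scatter) in this assay, and fluoro in place of chloro gives a 2.0-fold lower number from compound 1 to compound 3 (0.30 log units; within the scatter). Even the widest gap among hydrogen, fluoro and chloro stays within the scatter, so these three compounds cannot be told apart on these data. Nothing available explains the numbers at this position.

Going by these compounds, whether a methoxy group, an amine or a carboxylic acid at this place would give a step beyond the scatter remains open. Also open, on these data alone, is whether fluoro gives a similar step when trifluoromethyl on the other aromatic ring is replaced by a chloro or a methyl group.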